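Replacing Furan-2-yl with Methoxy on the Shared Core

The source may hold more compounds than are shown below. What is called first, only, known or untested is meant among the compounds shown, and "the series" means these compounds.

Measured in a functional assay on HCT-116 cells (Homo sapiens), read by MTT assay, with a stated time of 3 days; on this read-out lower numbers stand for stronger inhibition and higher numbers for weaker inhibition:
- Compound 1 `c1csc(Sc2c[nH]c3ncnc(-c4cccs4)c23)c1`: 13000 nM
- Compound 2 `c1coc(-c2ncnc3[nH]cc(Sc4cccs4)c23)c1`: 6750 nM

Only these two compounds have been measured, and their values lie within the scatter of each other, so neither stands apart. Compound 3 `COc1ncnc2[nH]cc(Sc3cccs3)c12` has yet to be measured in this assay. It differs from compound 2 by methoxy in place of furan-2-yl on an aromatic carbon.

Within the data shown here, one measured step bears on this change, and only in part. It is a 1.9-fold lower number from compound 1 to compound 2 (0.28 log units; within the scatter), with furan-2-yl in place of thiophen-2-yl on an aromatic carbon. Among the measured compounds shown here, that exchange kept a five-membered aromatic ring, whereas the new change removes one, and no measured compound shows the effect of such a loss. For the measured compounds named here, the small step between the two measured compounds therefore sets no direction, and no step clearly beyond the scatter is expected, though the uncertainty is wide. The expected step is a 1.8-fold higher number from compound 2 to compound 3 (0.25 log units; within the scatter). For compound 3 the estimated value is 12000 nM, with an expected range of 5000 nM to 40000 nM.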

Compound 3, half-maximal inhibitory concentration: 17200 nM
Compound 3: middle estimate off by 1.4-fold (0.16 log units), on the low side, and the stated range covers the measured number.
By their numbers in this assay, from the lowest: compounds 2, 1 and 3 (each within the scatter of the next, the first and the last beyond it).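

Among these compounds, measured in this assay the exchange of furan-2-yl for methoxy on this aromatic carbon, next to the ring nitrogen, gave the first step beyond the scatter, though a modest one (a 2.5-fold higher number from compound 2 to compound 3 (0.41 log units; beyond the scatter)). Until now the position had only seen one five-membered aromatic ring swapped for another; here the ring is lost and the group shrinks from five heavy atoms to two, and the number rises. The same methoxy exchange set against thiophen-2-yl stays within the scatter (a 1.3-fold higher number from compound 1 to compound 3 (0.12 log units; within the scatter)), so compound 1 goes against any general reading that losing the ring raises the number, and nothing available accounts for the difference between the two exchanges.

The three compounds cannot separate the loss of the aromatic ring from the shrinking of the group, since methoxy changes both at once. Going by these compounds, it also remains open how this position would respond to a phenyl ring, a longer chain such as butoxy, or an amine in place of the oxygen of methoxy.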